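This account rests on a few compounds, and the source may have more. Where it says the series, first, only, none or still open, it means among the compounds named here.

Measured compounds, with their read-out in a functional assay on HEK293 cells for agonist activity at metabotropic glutamate receptor 1 (Homo sapiens), read by a luciferase reporter and cAMP accumulation; on this read-out lower numbers stand for an effect already at smaller amounts and higher numbers for an effect only at larger amounts of compound; each of the three values is a limit of the assay rather than a number:
compound 1 `Fc1cc(Cl)ccc1N1CCN(Cc2ccn3c(CC4CC4)nnc3c2C(F)(F)F)CC1`: > 10000 nM
compound 2 `Fc1ccc(N2CCN(Cc3ccn4c(CC5CC5)nnc4c3C(F)(F)F)CC2)c(Cl)c1`: > 10000 nM
compound 3 `Fc1ccccc1N1CCN(Cc2ccn3c(CC4CC4)nnc3c2C(F)(F)F)CC1`: > 10000 nM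

Compound 3 stands at the limit: in this assay compound 3 gives > 10000 nM, a limit and not a number. Compound 1 likewise sits at a limit with > 10000 nM. Compound 2 also sits at a limit with > 10000 nM. None of the steps among these three can therefore be read: a step that the two limits leave unreadable from compound 1 to compound 2, a step that the two limits leave unreadable from compound 1 to compound 3 and a step that the two limits leave unreadable from compound 2 to compound 3. All three values sit at the limit of > 10000 nM in this assay, at which 3 of the 3 values shown sit.

Compound 4 `Fc1ccc(N2CCN(Cc3ccn4c(CC5CC5)nnc4c3C(F)(F)F)CC2)c(F)c1` differs from compound 3 in one place: fluoro in place of hydrogen on an aromatic carbon. Within the data shown here, no measured step bears on this change in a readable way, since the swaps of chloro, fluoro and hydrogen among the three measured compounds all remain unreadable because the limit of > 10000 nM in this assay, at which 3 of the 3 values shown sit, holds every value shown. Nothing in these data points to an effect within the range the assay reports, and the expectation is that compound 4 also falls at the limit, so that the step expected is a step that the limit leaves unreadable from compound 3 to compound 4. Compound 4 is thus estimated at 15000 nM, within 5000 nM to 50000 nM.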

Compound 4, half-maximal effective concentration: > 8000 nM
Compound 4 ended at the assay's limit; the forecaster's own chance of this, stated with the estimate: 85%; the middle value does not contradict the limit.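

Compound 4 joins compound 1, compound 2 and compound 3 at a limit in this assay rather than a number, so no step among these four compounds can be read. Left open is whether chloro, fluoro or hydrogen on this aromatic ring makes any difference, and whether any change to the shared core would bring a value within the range that this assay reports.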